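This account rests on a few compounds, and the source may have more. Where it says the series, first, only, none or still open, it means among the compounds named here.

Compound 1 `O/N=C(/Nc1ccccc1)c1ccc2occc2c1`: in an assay on isolated protein for inhibition of Indoleamine 2,3-dioxygenase 1 (Homo sapiens), read by spectrophotometry (on this read-out higher numbers stand for weaker inhibition and lower numbers for stronger inhibition), compound 1 gives > 30000 nM, a limit of the assay.
Compound 2 `O/N=C(/Nc1ccc(Cl)cc1)c1ccc2occc2c1`: compound 2 gives > 30000 nM, again a limit.
Compound 3 `O=C(NCC1CCCCC1)c1cccc(N/C(=N/O)c2ccc3occc3c2)c1`: compound 3 gives > 30000 nM, also a limit.

Compound 1 therefore stands only at a limit in this assay, with no number of its own, and the two other compounds shown stand at the same limit. For the measured compounds named here, the single step between measured compounds that differ in one place, a step that the two limits leave unreadable from compound 1 to compound 2, cannot be read, since both ends are limits. Compound 4 `O/N=C(/Nc1cccc(Oc2ccccc2)c1)c1ccc2occc2c1` differs from compound 1 by phenoxy in place of hydrogen on an aromatic carbon. Going by the values given here, no measured step bears directly on a phenoxy group; the only evidence is the limit of > 30000 nM in this assay, at which 3 of the 3 values shown sit, which gives no direction and no size for the step from compound 1 to compound 4. Compound 3, which carries a large group on the same ring, also sits at the limit. Compound 4 is therefore expected to remain near or beyond the limit, with the step that the limit leaves unreadable from compound 1 to compound 4 estimated as not readable; its value is estimated at 40000 nM, within 10000 nM to 200000 nM.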

Compound 4, half-maximal inhibitory concentration: > 30000 nM
Compound 4: no number, only a limit (the forecaster's own chance of this, stated with the estimate: 80%); the middle value does not contradict the limit.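

In this assay compound 4 gives > 30000 nM, a limit and not a number. Compound 1 also stands at a limit, so the step between compound 1 and compound 4 cannot be read. The compounds shown leave open whether any change to the shared core gives a readable value: the limit of > 30000 nM in this assay, at which 4 of the 4 values shown sit.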